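Solubility notes: cyanomethyl to ethyl on the shared core

This account rests on a few compounds, and the source may have more. Where it says the series, first, only, none or still open, it means among the compounds named here.

In a physicochemical assay for solubility (a higher number here means a more soluble compound, a lower number a less soluble compound), compound 1 `N#Cc1ncc(-n2c(=O)n(Cc3ccccc3)c3ccccc32)cc1C(F)(F)F` gives 5300 nM. Compound 2 `N#CCn1c(=O)n(-c2ccc(C#N)c(C(F)(F)F)c2)c2ccccc21` gives 18900 nM, the higher of the two numbers, and the gap to compound 1 lies beyond the scatter. Compound 3 `CCn1c(=O)n(-c2ccc(C#N)c(C(F)(F)F)c2)c2ccccc21` is not yet measured; it differs from compound 2 by methyl in place of cyano on a saturated chain carbon bound to an aromatic nitrogen. Going by the values given here, no measured pair covers this change, so the size of the step rests on judgement alone. A modest step downward is expected for compound 3, a 2.1-fold lower number from compound 2 to compound 3 (0.32 log units; beyond the scatter), close to the edge of the scatter. For compound 3 the expected value is 9000 nM, within 3500 nM to 25000 nM.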

Compound 3, solubility: 3470 nM
Beside the measured number, compound 3's estimate is 2.6-fold (0.41 log units) above it, and the stated range ends above it.
By their numbers in this assay, from the lowest: compounds 3 and 1 (each within the scatter of the next); then compound 2.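

This position is not silent in this assay: on the shared core, methyl in place of cyano on a saturated chain carbon bound to an aromatic nitrogen gives a 5.4-fold lower number from compound 2 to compound 3 (0.74 log units; beyond the scatter) and lies beyond the scatter. The earlier compounds shown here offered no pair for this change, and this single pair now gives it a measured size. Nothing on hand accounts for that size.

As far as these compounds go, whether the same step holds on another core remains open, since one pair stands behind it. Also open, from the compounds shown here alone, is how a longer chain, an amine or a carboxylic acid would read at this position.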